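The source may report more compounds than this note shows. Statements on the series, on what has been measured and on what is new or still open speak of the compounds shown alone.

Among the compounds with values here, compound 2 `COC(=O)/C=C/c1cccc(N(Cc2ccc(/C=C/c3c(C)cc(C)cc3C)cc2)C(=O)C(C)C)c1` gives the lowest of the two numbers in an assay on isolated protein with Bile acid receptor (Homo sapiens) as the target (on this read-out higher numbers stand for an effect only at larger amounts of compound and lower numbers for an effect already at smaller amounts), where it records 149 nM; compound 1 `COC(=O)/C=C/c1cccc(N(Cc2ccc(/C=C/c3ccccc3F)cc2)C(=O)NC(C)C)c1` gives 431 nM, a gap beyond the usual scatter, though the two differ in more than one place, so no single step is described. Compound 3 `COC(=O)/C=C/c1cccc(N(Cc2ccc(/C=C/c3c(C)cc(C)cc3C)cc2)C(=O)NC(C)C)c1` differs from compound 2 by isopropylamino in place of isopropyl on a carbonyl carbon. Within the data shown here, no measured pair isolates this change, so the step from compound 2 to compound 3 is expected to be small, a 1.3-fold higher number from compound 2 to compound 3 (0.13 log units; within the scatter), with no confident direction. Compound 3 is therefore estimated at 200 nM, within 70 nM to 600 nM.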

Compound 3, half-maximal effective concentration: 431 nM
Beside the measured number, compound 3's estimate is 2.2-fold (0.33 log units) below it; low and high end bracket the measured number.
By their numbers in this assay, from the lowest: compound 2; then compounds 1 and 3 (each within the scatter of the next).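

On the carbonyl carbon, isopropylamino in place of isopropyl gives a 2.9-fold higher number from compound 2 to compound 3 (0.46 log units; beyond the scatter), so with the 2,4,6-trimethylphenyl group held fixed, this position responds to the change. With isopropylamino held fixed, 2,4,6-trimethylphenyl in place of 2-fluorophenyl gives no change at the digits printed from compound 1 to compound 3 (within the scatter) on this read-out. Nothing available accounts for either step. On these data alone, whether a methylamino or a methoxy group on the same carbonyl carbon would read like isopropylamino or like isopropyl stays open. So does the size of the carbonyl step with 2-fluorophenyl in place.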